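Trifluoromethyl in place of fluoro in a seizure model

A few compounds are considered here, and "the series" means these few. Any claim that something is new, unique, unknown or untested is made for them only; others in the source may bear on it.

Compound 1 `CC(C(=O)N1CCN(c2ccccc2F)CC1)N1C(=O)CCC1=O` gives 25% in a functional assay on the whole organism (strain Swiss) with Mus musculus as the target, in the maximal electroshock model, with a stated time of 2 h, at a dose of 300 mg/kg by the intraperitoneal route; on this read-out higher numbers stand for a stronger effect at the one dose given and lower numbers for a weaker effect.
Compound 2 `CC(C(=O)N1CCN(c2ccc(C(F)(F)F)cc2)CC1)N1C(=O)CCC1=O` gives 0%.
Compound 3 `CC(C(=O)N1CCN(c2ccc(F)cc2)CC1)N1C(=O)CCC1=O` gives 50%.

Compound 3 and compound 1 are built from the same atoms, joined differently: 2-fluorophenyl in place of 4-fluorophenyl on an amine nitrogen in a ring. The step of a number 25 percentage points higher from compound 1 to compound 3 (beyond the scatter) is modest. The change trifluoromethyl in place of fluoro on an aromatic carbon brings a number 50 percentage points lower from compound 3 to compound 2 (beyond the scatter), the largest step among these three compounds. Compound 4 `CC(C(=O)N1CCN(c2ccccc2C(F)(F)F)CC1)N1C(=O)CCC1=O` has not been measured. It arises from compound 1 by the same kind of change, (trifluoromethyl in place of fluoro on an aromatic carbon), though here the new group sits ortho to a large group, whereas in compound 2 it sits para to a large group. Resting on the single earlier step of a number 50 percentage points lower from compound 3 to compound 2 (beyond the scatter), compound 4 is expected to show a number 25 percentage points lower from compound 1 to compound 4 (beyond the scatter) in this assay. Compound 4 is therefore estimated at 0%, between 0% and 25%. For the measured compounds named here, with only one example of this change, the expectation remains uncertain.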

Compound 4, a percentage reported as activity, at one dose (the size of the read-out at that dose, not a potency): 75%
The estimate for compound 4 lay 75 percentage points below the measured number; the measured number lies above the stated range.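

In this assay, trifluoromethyl in place of fluoro brings a number 50 percentage points higher from compound 1 to compound 4 (beyond the scatter), so on this core the change raises the number instead of lowering it. Set side by side, the two examples of the change disagree: the same change on two cores in this assay, a number 50 percentage points lower (beyond the scatter) from compound 3 to compound 2 and a number 50 percentage points higher (beyond the scatter) from compound 1 to compound 4, 100 percentage points apart, beyond the scatter of two such steps. For the compounds shown here, this shows that the result of the change on one core cannot simply be carried over to another, but with only two pairs it does not show what causes the reversal or which of the two results would be the more usual.

From the compounds shown here alone, what a chloro or a methoxy group would do on the same aromatic carbon, ortho to a large group, stays open. So does whether either of these groups would follow compound 4 or compound 2.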